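Configuration change at one stereocentre of compound 2

The source may report more compounds than this note shows. Statements on the series, on what has been measured and on what is new or still open speak of the compounds shown alone.

Among the measured compounds shown here, in a physicochemical assay for solubility, read by chemiluminescence, measured as kinetic solubility (on this read-out higher numbers stand for higher solubility and lower numbers for lower solubility), compound 1 `O=C([C@@H]1CCCN1)N1CCC2(CCN(c3nccc(NCc4ccc(Cl)cc4Cl)n3)CC2)C1` gives 165 ug/mL and compound 2 `Clc1ccc(CNc2ccnc(N3CCC4(CCN(C[C@H]5CCCN5)C4)CC3)n2)c(Cl)c1` gives 16 ug/mL, the lower of the two numbers so far. For the measured compounds named here, the only measured step, a 10-fold lower number from compound 1 to compound 2 (1.01 log units; beyond the scatter), is large and beyond the scatter. It puts (pyrrolidin-2-yl)methyl in place of (pyrrolidin-2-yl)carbonyl on an amine nitrogen in a ring, so it gives no size for a change of configuration alone. Next comes compound 3 `Clc1ccc(CNc2ccnc(N3CCC4(CCN(C[C@@H]5CCCN5)C4)CC3)n2)c(Cl)c1`: the two compounds have the same atoms and bonds and differ only in configuration as drawn: 1 of 1 stereo elements differ; a stereocentre at a saturated ring carbon is drawn R in compound 2 and S in compound 3. A stereocentre at a saturated ring carbon is drawn R in compound 2 and S in compound 3. Going by the values given here, no measured pair isolates such a change, so no step beyond the scatter is expected in this assay, and no direction is favoured. The expected step is no change at the digits printed from compound 2 to compound 3 (within the scatter). Anchored on compound 2 at 16 ug/mL, the estimate for compound 3 is 16 ug/mL, with an expected range of 8 ug/mL to 32 ug/mL.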

Compound 3, solubility: 56 ug/mL
Estimate against measurement, compound 3: 3.5-fold (0.54 log units) below, outside the stated range (above it).
By their numbers in this assay, from the lowest: compound 2; then compound 3; then compound 1.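

In this assay this position responds to configuration alone, with a 3.5-fold higher number from compound 2 to compound 3 (0.54 log units; beyond the scatter), so the linker is not the only feature that moves the number here. That step can be assigned entirely to the stereocentre at the saturated ring carbon: the fact that compounds 2 and 3 differ only in the configuration as drawn. The replacement of (pyrrolidin-2-yl)carbonyl by (pyrrolidin-2-yl)methyl therefore has no single size: it reads as a 10-fold lower number from compound 1 to compound 2 (1.01 log units; beyond the scatter) for the form drawn R but as a 2.9-fold lower number from compound 1 to compound 3 (0.47 log units; beyond the scatter) for the form drawn S, and compound 1 remains the highest of the three.

Open, from the compounds shown here alone, is whether the same order of the two configurations holds with the carbonyl link, or with a longer chain between the pyrrolidine and the amine nitrogen in the ring. Also open, going by these compounds, is whether a piperidine in place of the pyrrolidine keeps any dependence on configuration.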